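The source may report more compounds than this note shows. Statements on the series, on what has been measured and on what is new or still open speak of the compounds shown alone.

Compound 3 `CC(C)C(c1ccc(-c2ccc3cccc(F)c3c2)[nH]c1=O)C1SC(=O)NC1=O` was tested in an ADME assay on microsomes from liver (Homo sapiens) for metabolic stability (a lower number here means that the compound disappears faster, a higher number that the compound lasts longer), where compound 3 gives 1.87 h. The closest companion is compound 1 `CC(C)[C@H](C[C@H]1OC(=O)NC1=O)c1ccc(-c2ccc3cccc(F)c3c2)[nH]c1=O`, which in this assay gives 1.68 h, within the usual scatter of compound 3. Compound 2 `CCC(CC)C(/C=C1\OC(=O)NC1=O)c1ccc(-c2ccc3cccc(F)c3c2)[nH]c1=O` reaches only the limit of this assay, with > 3 h reported as a limit rather than a number. Compound 4 `CC(C)C(/C=C1/C(=O)NC(=O)N1C)c1ccc(-c2ccc3cccc(F)c3c2)[nH]c1=O` has not yet been measured in this assay; it differs from compound 3 in one place: a group of 9 heavy atoms (5 carbon, 2 nitrogen, 2 oxygen; one five-membered non-aromatic ring with 2 hetero atoms) in place of a group of 7 heavy atoms (3 carbon, 1 nitrogen, 2 oxygen, 1 sulfur; one five-membered non-aromatic ring with 2 hetero atoms), on a saturated chain carbon bound to an aromatic carbon and a saturated chain carbon. For the measured compounds named here, no measured pair shows this kind of exchange, so the step is expected to stay within the scatter: a 1.2-fold higher number from compound 3 to compound 4 (0.07 log units; within the scatter). Compound 4 is therefore estimated to give 2.2 h in this assay, with a range from 1 h to 4.5 h.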

Compound 4, half-life: > 3 h
Compound 4 was reported as a limit; the forecaster's own chance of this, stated with the estimate: 25%; middle value at least 1.3-fold (0.13 log units) away from the limit.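

On the saturated chain carbon bound to an aromatic carbon and a saturated chain carbon, replacing the 2,4-dioxo-1,3-thiazolidin-5-yl group with the larger ring that holds no sulfur gives an at least 1.6-fold higher number from compound 3 to compound 4 (0.20 log units; that floor lies within the scatter). For the compounds shown here, this is the first single-place change that can be read here, and it shows that the ring sulfur is not needed for the compound to last in this assay. The result for compound 4 is a limit, so the step has only a floor and no full size: the limit of > 3 h in this assay, at which 2 of the 4 values shown sit.

Going by these compounds, how much longer compound 4 lasts remains open. Also open, on these data alone, is how a carboxylic acid or an amine at this place would behave in this assay.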